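Morpholine for Piperidine on a Longer Amide Tether

The source may hold more compounds than are shown below. What is called first, only, known or untested is meant among the compounds shown, and "the series" means these compounds.

Four amides built on one shared core are compared in a functional assay on U-937 cells (Homo sapiens) for antiproliferative activity, read by MTT assay, with a stated time of 24 h; a higher number here means a weaker inhibitor, a lower number a stronger inhibitor. Compound 1 `CCCCc1oc2ccccc2c1C(=O)c1ccc(OCC(=O)N2CCCCC2)cc1` gives 37100 nM there, and compound 2 `CCCCc1oc2ccccc2c1C(=O)c1ccc(OCC(=O)N2CCOCC2)cc1` gives 45400 nM. The two differ in one spot, (morpholin-4-yl in place of piperidin-1-yl on a carbonyl carbon), and the step of a 1.2-fold higher number from compound 1 to compound 2 (0.09 log units; within the scatter). Compound 3 `CCCCc1oc2ccccc2c1C(=O)c1ccc(OCCCC(=O)N2CCCCC2)cc1` keeps the core of compound 1 but carries a longer tether, (2-((piperidin-1-yl)carbonyl)ethyl in place of (piperidin-1-yl)carbonyl on a saturated chain carbon bound to an oxygen on an aromatic ring); in this assay compound 3 gives 16600 nM, with a 2.2-fold lower number from compound 1 to compound 3 (0.35 log units; beyond the scatter) and a 2.7-fold lower number from compound 2 to compound 3 (0.44 log units; beyond the scatter). Compound 4 `CCCCc1oc2ccccc2c1C(=O)c1ccc(OCCCC(=O)N2CCOCC2)cc1` is not yet measured. Relative to compound 3 the change is morpholin-4-yl in place of piperidin-1-yl on a carbonyl carbon, the same change as that made from compound 1 to compound 2, at the same place on the carbonyl carbon. Resting on the earlier step of a 1.2-fold higher number from compound 1 to compound 2 (0.09 log units; within the scatter), which stayed within the scatter, compound 4 is expected to show a step of about a 1.2-fold higher number from compound 3 to compound 4 (0.08 log units; within the scatter). The estimate for compound 4 in this assay is therefore 20000 nM, most likely falling between 10000 nM and 40000 nM.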

Compound 4, half-maximal inhibitory concentration: 21400 nM
Estimate against measurement, compound 4: 1.1-fold (0.03 log units) below, within the range that was stated.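

In this assay, the move to morpholin-4-yl on the longer tether gives a 1.3-fold higher number from compound 3 to compound 4 (0.11 log units; within the scatter), and it matches the same change on the shorter tether: the same change on two cores in this assay, a 1.2-fold higher number (0.09 log units; within the scatter) from compound 1 to compound 2 and a 1.3-fold higher number (0.11 log units; within the scatter) from compound 3 to compound 4, 1.1-fold (0.02 log units) apart, within the scatter of two such steps

Lengthening the tether in the morpholine amides gives a 2.1-fold lower number from compound 2 to compound 4 (0.33 log units; beyond the scatter), whereas changing the tether and the amide ring together gives a 1.7-fold lower number from compound 1 to compound 4 (0.24 log units; within the scatter). Within the data shown here, the piperidine-to-morpholine change therefore carried over between these two cores with no difference beyond the scatter, but each step is itself within the scatter, so this shows only that the change left the number about where it was on both tethers, not that it would do so on any other core.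

The compounds shown leave open whether this would still hold on a longer chain as the tether, or with a pyrrolidine or piperazine ring on the carbonyl carbon. They also leave open whether a group other than butyl on the shared core would alter the picture.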